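Swapping trifluoromethyl for cyclopropyl on the shared core

The source may report more compounds than this note shows. Statements on the series, on what has been measured and on what is new or still open speak of the compounds shown alone.

Measured so far:
compound 1 `CC(C)(O)c1cncc(-n2ncc3ccccc32)c1`: 535 nM
compound 2 `CC(C)(O)c1cncc(-n2nc(C(F)(F)F)c3ccccc32)c1`: > 8300 nM

In an ADME assay on cells for inhibition of cytochrome P450 11B1, mitochondrial (Homo sapiens), read by HTRF, with stated times of 1 h and 3 h (a lower number here means a stronger inhibitor, a higher number a weaker inhibitor), compound 1 gives 535 nM. Compound 2 gives only a limit, > 8300 nM, not a number. Compound 2 stands at the limit of > 8300 nM in this assay, at which 1 of the 2 values shown sits. For the measured compounds named here, the one measured step, an at least 15-fold higher number from compound 1 to compound 2 (1.19 log units; beyond the scatter), shows that a trifluoromethyl at this place weakens inhibition strongly. Compound 3 `CC(C)(O)c1cncc(-n2nc(C3CC3)c3ccccc32)c1` differs from compound 2 by cyclopropyl in place of trifluoromethyl on an aromatic carbon. Going by the values given here, no measured step covers cyclopropyl at this place, so the expectation rests only on the loss seen from compound 1 to compound 2, and compound 3 is expected to stay weak, with a step of roughly an at least 1.3-fold lower number from compound 2 to compound 3 (0.14 log units; that floor lies within the scatter). Compound 3 is estimated at 6000 nM, between 900 nM and 25000 nM.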

Compound 3, half-maximal inhibitory concentration: > 8300 nM
Compound 3 gave a limit, no number; the forecaster's own chance of this, stated with the estimate: 45%; middle value at least 1.3-fold (0.14 log units) away from the limit.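

Cyclopropyl in place of hydrogen at this place gives an at least 15-fold higher number from compound 1 to compound 3 (1.19 log units; beyond the scatter) in this assay. The strong loss is therefore not confined to trifluoromethyl: with hydrogen replaced by either of these two groups on this aromatic carbon, inhibition is much weaker. Compound 2 and compound 3 both give limits, not numbers, so the step between them cannot be read: the limit of > 8300 nM in this assay, at which 2 of the 3 values shown sit.

The compounds shown leave open whether any group here other than hydrogen keeps inhibition, for example a methyl, an amine or a carboxylic acid. As far as these compounds go, how much weaker than compound 1 these two compounds really are also stays unknown.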